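The source may hold more compounds than are shown below. What is called first, only, known or untested is meant among the compounds shown, and "the series" means these compounds.

Compound 1 `O=C(Nc1cccc(-n2cc(-c3ccncc3)c(-c3ccc(Cl)c(O)c3)n2)c1)Nc1cccc(C(F)(F)F)c1`: 509 nM in a functional assay on HOP-92 cells (Homo sapiens) for inhibition, read by sulforhodamine B assay, with a stated time of 48 h; a higher number here means a weaker inhibitor of growth, a lower number a stronger inhibitor of growth
Compound 2 `O=C(Nc1cccc(-n2cc(-c3ccncc3)c(-c3ccc(Cl)c(O)c3)n2)c1)Nc1ccc(Cl)c(Cl)c1`: 679 nM

On these two numbers compound 1 gives the lower value, but the step of a 1.3-fold higher number from compound 1 to compound 2 (0.13 log units; within the scatter) is within the scatter, so the two compounds cannot be told apart in this assay.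

Compound 3 `O=C(Nc1cccc(-n2cc(-c3ccncc3)c(-c3ccc(Cl)c(O)c3)n2)c1)Nc1cc(C(F)(F)F)cc(C(F)(F)F)c1` has not yet been measured. It differs from compound 1 by trifluoromethyl in place of hydrogen on an aromatic carbon. Going by the values given here, the only measured step that bears on this change is the one from compound 1 to compound 2, which also altered the ring on the amide-type nitrogen and gave a 1.3-fold higher number from compound 1 to compound 2 (0.13 log units; within the scatter), within the scatter. A second trifluoromethyl on that ring is therefore expected to move the number little, if at all beyond the scatter: the estimated step is a 1.2-fold higher number from compound 1 to compound 3 (0.07 log units; within the scatter). Compound 3 is thus estimated at 600 nM in this assay, with a range from 250 nM to 1500 nM.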

Compound 3, concentration for 50% growth inhibition: 344 nM
Estimate against measurement, compound 3: 1.7-fold (0.24 log units) above, within the range that was stated.
By their numbers in this assay, from the lowest: compounds 3, 1 and 2 (each within the scatter of the next).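

Placing a second trifluoromethyl on an aromatic carbon, meta to the first, gives a 1.5-fold lower number from compound 1 to compound 3 (0.17 log units; within the scatter) in this assay. This carbon of the ring therefore accepts four more heavy atoms without any change that this assay can distinguish from the scatter, whereas the earlier step replaced one substitution pattern with another and did not test an addition at this carbon. No measurement shown here offers an explanation for this result.

From the compounds shown here alone, what stays open is whether any group at this carbon can move the number beyond the scatter, in either direction. An amine or a carboxylic acid in place of the second trifluoromethyl would test this, since the groups shown so far on this ring are only trifluoromethyl and chlorine.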